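Swapping butyl for sec-butyl on the sulfur

The source may report more compounds than this note shows. Statements on the series, on what has been measured and on what is new or still open speak of the compounds shown alone.

Values in a functional assay on MT4 cells (Homo sapiens) for cytotoxicity; on this read-out lower numbers stand for higher toxicity in this test and higher numbers for lower toxicity in this test:
- Compound 1 `CSc1nc(O)cc(C(C)c2c(F)cccc2F)n1`: 20800 nM
- Compound 2 `CCCCSc1nc(O)cc(C(C)c2c(F)cccc2F)n1`: > 200000 nM (a limit of the assay, not a number)

Compound 2 stands at the limit of > 200000 nM in this assay, at which 1 of the 2 values shown sits, so its place on the scale is known only as a limit.

The next compound to be read in this assay is compound 3 `CCC(C)Sc1nc(O)cc(C(C)c2c(F)cccc2F)n1`. It has the same atoms as compound 2, joined differently: sec-butyl in place of butyl on a sulfur. In words, sec-butyl takes the place of butyl on a sulfur.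

Within the data shown here, only one measured step bears on this change, and it concerns the same chain on the sulfur: an at least 9.6-fold higher number from compound 1 to compound 2 (0.98 log units; beyond the scatter). That step is beyond the scatter, but it compares a short chain with a longer one. Among the measured compounds shown here, no measured pair compares a straight chain with a branched one of the same count. With the chain count unchanged, no step beyond the scatter is expected, and a reading at the limit again would be no surprise.

The expected change is an at least 1.1-fold lower number from compound 2 to compound 3 (0.04 log units; that floor lies within the scatter).

Compound 3 is estimated at 180000 nM, with an expected range from 70000 nM to 300000 nM.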

Compound 3, half-maximal cytotoxic concentration: > 200000 nM
Compound 3: no number, only a limit; the forecaster's own chance of this, stated with the estimate: 55%; middle value at least 1.1-fold (0.04 log units) from the limit.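

Compound 3 shows that the high reading in this assay does not depend on a straight chain on the sulfur: with sec-butyl in place of butyl, the compound again sits at a limit of the assay rather than at a number. Set against the methyl group, sec-butyl gives an at least 9.6-fold higher number from compound 1 to compound 3 (0.98 log units; beyond the scatter), so a second four-carbon chain of a different shape joins butyl in lying beyond the scatter from methyl. The step between butyl and sec-butyl itself cannot be read, and whether the branch changes anything stays hidden, because both compounds rest at the same ceiling: the limit of > 200000 nM in this assay, at which 2 of the 3 values shown sit.

Left open is where between methyl and butyl the reading in this assay leaves the measurable range, which an ethyl or propyl chain on the sulfur could help to place. Going by these compounds, it is also open whether the trend holds for groups of another kind on the sulfur, such as a cyclohexyl ring or a chain ending in an amine.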